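Swapping a hydroxy for a sulfanyl on a weakly toxic scaffold

A few compounds are considered here, and "the series" means these few. Any claim that something is new, unique, unknown or untested is made for them only; others in the source may bear on it.

Of the compounds shown here, three have been tested in a functional assay on CCRF-CEM cells (Homo sapiens) for cytotoxicity; on this read-out higher numbers stand for lower toxicity in this test and lower numbers for higher toxicity in this test. Compound 1 `O=c1[nH]c(=S)[nH]c2c(CCCCCOCc3ccccc3)ncn12` gives 259000 nM in this assay. Compound 3 `Cc1nc(Cc2ccccc2)c2ncnc(O)n12` gives 263000 nM in this assay. Compound 2 `Cc1ccc(Cc2ncn3c(O)ncnc23)cc1` reaches only a limit in this assay, reported as > 833000 nM. That is not a measured number but the edge of what this assay can resolve, and it is the limit (the limit of > 833000 nM in this assay, at which 1 of the 3 values shown sits). On the numbers shown, compound 2 therefore stands at the least toxic end, with no exact value behind it.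

Compound 4 `Cc1ccc(Cc2ncn3c(S)ncnc23)cc1` has not yet been measured in this assay. It differs from compound 2 in one place: sulfanyl in place of hydroxy on an aromatic carbon. Within the data shown here, no pair of measured compounds that differs in this one place exists here, so the size of the step cannot be read from the data. Compound 1 carries a sulfur on its core and compound 3 a hydroxy, and their values sit close to each other, which gives no sign that the swap alone moves cytotoxicity far.

The expectation for compound 4 in this assay is therefore a value near the weak end, estimated at 600000 nM, within 200000 nM to 1000000 nM. The step this estimate implies, an at least 1.3-fold lower number from compound 2 to compound 4 (0.14 log units; that floor lies within the scatter), is expected to be small, and the assay may again return only a limit.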

Compound 4, half-maximal cytotoxic concentration: 32800 nM
For compound 4 the middle estimate is 18-fold (1.26 log units) above the measured one; the measured number lies below the stated range.
By their numbers in this assay, from the lowest: compound 4; then compounds 1 and 3 (each within the scatter of the next). At a limit, above all of these: compound 2.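

In this assay, sulfanyl in place of hydroxy on the aromatic carbon between two ring nitrogen atoms brings an at least 25-fold lower number from compound 2 to compound 4 (1.40 log units; beyond the scatter), and a lower number here means higher toxicity in this test. Among these compounds, the earlier compounds held no pair differing only in this place, so this is the first direct reading of the change, and it shows that exchanging this single atom, oxygen for sulfur, at this position is enough to shift the read-out well beyond the usual scatter. Compound 2 is reported only as a limit, so the step has a floor but no known upper end: the limit of > 833000 nM in this assay, at which 1 of the 4 values shown sits.

The compounds shown cannot tell whether this rise in toxicity is specific to sulfanyl or whether other groups on the same carbon, such as an amine or a chlorine atom, would move the read-out as well. Going by these compounds, it also remains open whether the same swap would have an effect of this size if a longer chain took the place of the substituted benzyl group on the shared core.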